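The compounds below may be only part of what the source reports. "The series", "measured", "known", "first", "only" and "open" are said of these compounds alone.

In a physicochemical assay, read by spectrophotometry, with a stated time of 30 min (on this read-out lower numbers stand for stronger inhibition and higher numbers for weaker inhibition), the three measured compounds stand as follows:
compound 1 `O=C(CCc1nc2ccccc2c(=O)[nH]1)N/N=C/c1ccc([N+](=O)[O-])cc1` gives 328000000 nM
compound 2 `O=C(CCCc1nc2ccccc2c(=O)[nH]1)N/N=C/c1ccc(Cl)cc1` gives 353000000 nM
compound 3 `COc1ccc(/C=N/NC(=O)CCCc2nc3ccccc3c(=O)[nH]2)cc1` gives 247000000 nM

Compound 1 stands second highest of the three numbers; its nearest neighbour is compound 2 and its furthest is compound 3, and both gaps lie within the scatter. The step from compound 1 to compound 4 `COc1cc(/C=N/NC(=O)CCc2nc3ccccc3c(=O)[nH]2)ccc1O` is 4-hydroxy-3-methoxyphenyl in place of 4-nitrophenyl on a carbon with a double bond to nitrogen. Within the data shown here, the one measured step that bears on it is a change of substituent on the same aromatic ring: a 1.4-fold lower number from compound 2 to compound 3 (0.16 log units; within the scatter). Nothing measured here separates one aryl substitution from another beyond the scatter, so in this assay no step beyond the scatter is expected. Compound 4 is therefore expected to give about 300000000 nM, between 150000000 nM and 600000000 nM. The expected step is a 1.1-fold lower number from compound 1 to compound 4 (0.04 log units; within the scatter).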

Compound 4, half-maximal inhibitory concentration: 204000000 nM
Beside the measured number, compound 4's estimate is 1.5-fold (0.17 log units) above it; low and high end bracket the measured number.
By their numbers in this assay, from the lowest: compounds 4, 3, 1 and 2 (each within the scatter of the next).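

In this assay, the exchange of 4-nitrophenyl for 4-hydroxy-3-methoxyphenyl on a carbon with a double bond to nitrogen gives a 1.6-fold lower number from compound 1 to compound 4 (0.21 log units; within the scatter) and thus replaces a whole substituted aryl group, where the earlier step changed a single substituent. Even with a hydrogen-bond donor entering, the step stays within the scatter. No measurement at hand explains this result.

The compounds shown leave open whether any aryl group at this place can move the number beyond the scatter. Whether an amine or a carboxylic acid on the ring would do so remains unsettled.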